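Swapping Hydroxy for Dimethylamino: From Compound 2 to Compound 4

The compounds below may be only part of what the source reports. "The series", "measured", "known", "first", "only" and "open" are said of these compounds alone.

The three measured compounds share one core and differ only in the substituents on the outer aromatic ring. Compound 1 `O=C(N/N=C/c1ccc(Cl)cc1)c1cccnc1Nc1cccc(C(F)(F)F)c1` carries chloro there, and in a functional assay on the whole organism (strain Wistar) for inhibition, with Rattus norvegicus as the target, read by paw edema, with a stated time of 30 min, at a dose of 10 mg/kg by the intraperitoneal route (a higher number here means more inhibition at the dose given (going by the name of the read-out), a lower number less inhibition), compound 1 gives 52.4%. Compound 2 `O=C(N/N=C/c1ccc(O)cc1)c1cccnc1Nc1cccc(C(F)(F)F)c1` carries hydroxy in the same position, and in this assay compound 2 gives 59.3%. Compound 3 `COc1cc(/C=N/NC(=O)c2cccnc2Nc2cccc(C(F)(F)F)c2)cc(OC)c1OC` bears three methoxy groups on that ring, and in this assay compound 3 gives 55.9%. Compound 2 holds the highest of the three numbers, but its gaps to compound 3 and to compound 1 both lie within the scatter, so no order among the three can be read from these data.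

The unmeasured compound 4 `CN(C)c1ccc(/C=N/NC(=O)c2cccnc2Nc2cccc(C(F)(F)F)c2)cc1` differs from compound 2 by dimethylamino in place of hydroxy on an aromatic carbon. Among the compounds with values here, only one measured step touches this same place: a number 6.9 percentage points higher from compound 1 to compound 2 (within the scatter), which stayed within the scatter. Within the data shown here, no measured step involves dimethylamino, and the trimethoxy compound 3 sits in the same narrow band as the other two. One therefore expects a number 3.3 percentage points lower from compound 2 to compound 4 (within the scatter) to stay within the scatter, in no particular direction. Compound 4 is estimated at 56%, with a range from 45% to 67%.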

Compound 4, a percentage reported as inhibition, in the whole organism at one dose (the size of the read-out at that dose, not a potency): 61.3%
The estimate for compound 4 lay 5.3 percentage points below the measured number; low and high end bracket the measured number.
By their numbers in this assay, from the lowest: compounds 1, 3, 2 and 4 (each within the scatter of the next).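

In this assay, the change from 4-hydroxyphenyl to 4-(dimethylamino)phenyl gives a number 2 percentage points higher from compound 2 to compound 4 (within the scatter), and the step from chloro to dimethylamino gives a number 8.9 percentage points higher from compound 1 to compound 4 (within the scatter). Within the data shown here, until now, the only single-place step at this position was between chloro and hydroxy; these new steps show that a group with more heavy atoms and no hydrogen-bond donor can stand on this aromatic carbon with the read-out staying within the scatter of both earlier groups. The hydrogen-bond donor of hydroxy is therefore not needed at this position to keep the number in this band at the dose given, and nothing here bears on a cause for this result.

What the compounds shown leave open is whether any group at this position can move the number beyond the scatter, since the four compounds form one unbroken band; a carboxylic acid, a primary amine or a longer alkoxy chain in place of dimethylamino would test that. They also leave open whether the same band would hold at another dose or another time point.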